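The source may report more compounds than this note shows. Statements on the series, on what has been measured and on what is new or still open speak of the compounds shown alone.

Compound 3 `CCCCn1cnc2c(Nc3ccc(Cl)cc3)nc(N[C@H]3CC[C@H](N)CC3)nc21` sits second highest of the three numbers in a functional assay on HCC827 cells (Homo sapiens) for inhibition, read by fluorescence, with a stated time of 72 h (a higher number here means a weaker inhibitor of growth, a lower number a stronger inhibitor of growth), where compound 3 gives 10800 nM. Compound 2 `CCCCCCn1cnc2c(Nc3cccc(Cl)c3)nc(N[C@H]3CC[C@H](N)CC3)nc21` gives 10200 nM, a number within the scatter of that of compound 3, while compound 1 `CCCCCCn1cnc2c(Nc3ccc(O)cc3)nc(N[C@H]3CC[C@H](N)CC3)nc21` gives 24700 nM, a number beyond the scatter above it. Compound 4 `CCCCCCn1cnc2c(Nc3ccc(Cl)cc3)nc(N[C@H]3CC[C@H](N)CC3)nc21` differs from compound 3 only by ethyl in place of hydrogen on a saturated chain carbon, four bonds along the chain from an aromatic nitrogen. Among the measured compounds shown here, the single measured step, a 2.4-fold lower number from compound 1 to compound 2 (0.38 log units; beyond the scatter), concerns the group on the aromatic amine, not the chain, so it offers no direct guide here; compounds 2 and 3 differ in both the chain and the ring group, and their two values are within the scatter of each other. For the measured compounds named here, with no step bearing on the chain, compound 4 is expected to show no change at the digits printed from compound 3 to compound 4 (within the scatter), and its estimated value is 10800 nM, ranging from 5000 nM to 23000 nM.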

Compound 4, concentration for 50% growth inhibition: 11700 nM
For compound 4 the middle estimate is 1.1-fold (0.03 log units) below the measured one; measured number inside the range.
By their numbers in this assay, from the lowest: compounds 2, 3 and 4 (each within the scatter of the next); then compound 1.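

In this assay, ethyl in place of hydrogen at this chain carbon gives a 1.1-fold higher number from compound 3 to compound 4 (0.03 log units; within the scatter), so this change in the chain leaves the number within the scatter. Among the compounds shown here, with the hexyl-bearing compounds, 4-chlorophenyl in place of 3-chlorophenyl gives a 1.1-fold higher number from compound 2 to compound 4 (0.06 log units; within the scatter), while chloro in place of hydroxy on the aromatic carbon gives a 2.1-fold lower number from compound 1 to compound 4 (0.32 log units; beyond the scatter), the only one of these steps beyond the scatter. Nothing measured here explains these results. As far as these compounds go, whether a longer chain, or an amine or carboxylic acid at the chain's end, would move the number remains open.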